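This account rests on a few compounds, and the source may have more. Where it says the series, first, only, none or still open, it means among the compounds named here.

In an ADME assay on J774.A1 cells (Mus musculus) for inhibition, read by MTT assay, with a stated time of 72 h (a lower number here means that less compound is needed, a higher number that more compound is needed for the effect), compound 1 `CC(C)Nc1nc(NCc2ccco2)c2ccccc2n1` gives 17000 nM and compound 2 `CC(C)Nc1nc(NC2CC2)c2ccccc2n1` gives 31000 nM as its number. These two values lie within the usual scatter of each other, so the data do not separate compound 2 from compound 1. Compound 3 `CCNc1nc(NC(C)C)nc2ccccc12` has not yet been measured. It differs from compound 2 in one place, described by ethyl in place of cyclopropyl on a nitrogen on an aromatic ring as the exchange: ethyl in place of cyclopropyl on a nitrogen on an aromatic ring. Going by the values given here, the only measured step at that nitrogen is a 1.8-fold higher number from compound 1 to compound 2 (0.26 log units; within the scatter) and, as it stays within the scatter, no step beyond the scatter is expected for this new exchange. The estimated change is a 1.1-fold lower number from compound 2 to compound 3 (0.04 log units; within the scatter) with no clear direction expected. For compound 3 the estimate is 28000 nM with an expected range from 13000 nM to 60000 nM in this assay once it is tested.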

Compound 3, half-maximal effective concentration: > 30000 nM
Compound 3: only a limit was reported (the forecaster's own chance of this, stated with the estimate: 10%); middle value at least 1.0-fold (0.02 log units) from the limit.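

In this assay compound 3 gives > 30000 nM as a limit of the assay and not a number. The step from the cyclopropyl compound to the ethyl compound cannot be read, because only a limit stands on one side of it: the limit of > 30000 nM in this assay, at which 1 of the 3 values shown sits. Going by these compounds alone, what can be read is an at least 1.7-fold higher number from compound 1 to compound 3 (0.24 log units; that floor lies within the scatter) and, as this is only a floor, the true step may be larger; with ethyl, the first group on this nitrogen that has no ring, nothing suggests that less compound is needed.

As far as these compounds go, whether ethyl and cyclopropyl truly differ here stays open, since the real number for compound 3 is unknown. Also open, from the compounds shown here alone, is how a longer chain, or a chain ending in an amine or a carboxylic acid, would behave on this nitrogen.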